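The compounds below may be only part of what the source reports. "The series", "measured", "known", "first", "only" and "open" are said of these compounds alone.

Compound 1 `Cc1ccc(-c2nn(-c3ccccc3)cc2-c2nc3ccccc3n2C(=O)c2cncc(C)c2)cc1` gives 155000 nM in an ADME assay on HEK-293T cells (Homo sapiens) for cytotoxicity, read by MTT assay, with a stated time of 24 h; a higher number here means that more compound is tolerated, a lower number that less compound is tolerated.
Compound 2 `Cc1ccc(-c2nn(-c3ccccc3)cc2-c2nc3ccccc3n2C(=O)c2cccnc2)cc1` gives 189000 nM.

Among the measured compounds shown here, compound 2 stands highest of the two numbers measured, with compound 1 nearest; the only measured step, a 1.2-fold higher number from compound 1 to compound 2 (0.09 log units; within the scatter), lies within the scatter. Compound 3 `Cc1ccc(-c2nn(-c3ccccc3)cc2-c2nc3ccccc3n2C(=O)c2ccncc2)cc1` differs from compound 2 by pyridin-4-yl in place of pyridin-3-yl on a carbonyl carbon. For the measured compounds named here, no measured step moves the nitrogen within this ring; the one step available concerns a different part of the molecule and was itself within the scatter, so no step beyond the scatter is expected here. Compound 3 is therefore estimated at 180000 nM, with a range from 90000 nM to 360000 nM, meaning an expected step of a 1.1-fold lower number from compound 2 to compound 3 (0.02 log units; within the scatter).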

Compound 3, half-maximal cytotoxic concentration: 154000 nM
Compound 3: the middle estimate sits 1.2-fold (0.07 log units) above what was measured, and the stated range covers the measured number.
By their numbers in this assay, from the lowest: compounds 3, 1 and 2 (each within the scatter of the next).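

Moving the ring nitrogen, with pyridin-4-yl in place of pyridin-3-yl on a carbonyl carbon, gives a 1.2-fold lower number from compound 2 to compound 3 (0.09 log units; within the scatter) in this assay, and pyridin-4-yl in place of 5-methylpyridin-3-yl gives a 1.0-fold lower number from compound 1 to compound 3 (0.00 log units; within the scatter). The place of the ring nitrogen, like the methyl before it, therefore makes no difference beyond the scatter among these three groups. Nothing measured here bears on why these numbers stay so close.

From the compounds shown here alone, it remains open whether pyridin-2-yl or cyclohexyl on that carbonyl carbon would also stay within the scatter in this assay.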